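Nucleoside series: methyl and thiophenyl changes, one cell assay

This account rests on a few compounds, and the source may have more. Where it says the series, first, only, none or still open, it means among the compounds named here.

The four compounds share one nucleoside core. Compound 1 is `Cc1ncnc2c1c(I)cn2[C@@H]1O[C@H](CO)[C@@H](O)[C@H]1O`, compound 2 is `CNc1ncnc2c1c(I)cn2[C@@H]1O[C@H](CO)[C@@H](O)[C@H]1O`, compound 3 is `CNc1ncnc2c1c(-c1ccsc1)cn2[C@@H]1O[C@H](CO)[C@@H](O)[C@H]1O`, and compound 4, still unmeasured, is `Cc1ncnc2c1c(-c1ccsc1)cn2[C@@H]1O[C@H](CO)[C@@H](O)[C@H]1O`.

In a functional assay on K562 cells (Homo sapiens), read by MTT assay, with a stated time of 72 h (a lower number here means a stronger inhibitor, a higher number a weaker inhibitor), compound 1 returns only a limit of the assay, > 20000 nM. Compound 2 likewise returns only a limit in this assay, > 20000 nM. Compound 3 also returns only a limit in this assay, > 20000 nM. All three measured values sit at the limit of > 20000 nM in this assay, at which 3 of the 3 values shown sit.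

Two single changes connect the measured compounds. From compound 2 to compound 1 the change is methyl in place of methylamino on an aromatic carbon; the step that the two limits leave unreadable from compound 2 to compound 1 is not readable, both values being limits. From compound 2 to compound 3 the change is thiophen-3-yl in place of iodo on an aromatic carbon; the step that the two limits leave unreadable from compound 2 to compound 3 is equally unreadable, for the same reason of two limits.

Compound 4 differs from compound 3 by methyl in place of methylamino on an aromatic carbon. This is the same change as from compound 2 to compound 1, at a place described in identical words; the two cores differ by thiophen-3-yl in place of iodo on an aromatic carbon.

For compound 4 in this assay an unreadable step that the limit leaves unreadable from compound 3 to compound 4 is expected, because compound 3 already sits at the limit of > 20000 nM in this assay, at which 3 of the 3 values shown sit, and the earlier instance of this change gave nothing readable. Compound 4 is therefore estimated at 30000 nM in this assay, most probably reported again as a limit rather than a number.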

Compound 4, half-maximal inhibitory concentration: 5550 nM
Beside the measured number, compound 4's estimate is 5.4-fold (0.73 log units) above it; the whole stated range lies above it.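

In this assay, for the compounds shown here, methyl in place of methylamino on the core carrying thiophen-3-yl gives an at least 3.6-fold lower number from compound 3 to compound 4 (0.55 log units; beyond the scatter), and thiophen-3-yl in place of iodo on the core carrying methyl gives an at least 3.6-fold lower number from compound 1 to compound 4 (0.55 log units; beyond the scatter), so compound 4, which holds both groups, is the only compound of the four with a measured number. The same two changes made from compound 2 cannot be read, so the methyl change has a visible result on one core only, and nothing shows that it acts to a similar extent on the core with iodo. The two readable steps are lower bounds on their size, and neither the true size of either step nor any difference between the cores can be stated: the limit of > 20000 nM in this assay, at which 3 of the 4 values shown sit.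

On these data alone, it remains open whether the result in this assay is specific to methyl or would also appear with ethyl, a primary amine or a plain hydrogen on the same aromatic carbon. As far as these compounds go, it is equally open whether thiophen-3-yl is particular in this pairing, or whether phenyl or furan-3-yl in its place, alongside methyl, would give a number rather than a limit.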